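The source may hold more compounds than are shown below. What is called first, only, known or untested is meant among the compounds shown, and "the series" means these compounds.

Compound 1 `C/C(=C\c1ccc(NC(=O)Nc2ccc(Cl)c(C(F)(F)F)c2)cc1)C(=O)NC(C)c1ccccc1` gives > 50000 nM
Compound 2 `CNC(=O)/C=C/c1ccc(NC(=O)Nc2ccc(Cl)c(C(F)(F)F)c2)cc1` gives 21200 nM

For the measured compounds named here, in a functional assay on KETR3 cells (Homo sapiens) for inhibition, read by MTT assay, with a stated time of 120 h (on this read-out lower numbers stand for stronger inhibition and higher numbers for weaker inhibition), compound 2 gives 21200 nM as the only actual number so far. Compound 1 gives > 50000 nM as a limit of the assay and not a number. Compound 3 `CNC(=O)/C(C)=C/c1ccc(NC(=O)Nc2ccc(Cl)c(C(F)(F)F)c2)cc1` is still to be measured. It differs from compound 2 in one place, on an aromatic carbon (2-(methylcarbamoyl)prop-1-en-1-yl in place of 2-(methylcarbamoyl)ethenyl on an aromatic carbon), with 2-(methylcarbamoyl)prop-1-en-1-yl in place of 2-(methylcarbamoyl)ethenyl. Going by the values given here, no measured step speaks to this change, so the expected step of a 1.0-fold higher number from compound 2 to compound 3 (0.02 log units; within the scatter) is none beyond the scatter. Compound 3 is estimated at 22000 nM in this assay, with 9000 nM to 50000 nM as its expected range.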

Compound 3, half-maximal inhibitory concentration: > 50000 nM
Compound 3 ended at the assay's limit; the forecaster's own chance of this, stated with the estimate: 20%; middle value at least 2.2-fold (0.35 log units) away from the limit.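

In this assay compound 3 gives > 50000 nM, which is a limit of the assay and not a number. For the compounds shown here, on an aromatic carbon para to a large group, 2-(methylcarbamoyl)prop-1-en-1-yl in place of 2-(methylcarbamoyl)ethenyl gives an at least 2.3-fold higher number from compound 2 to compound 3 (0.37 log units; beyond the scatter), the first readable step, and it points to weaker inhibition. The step between compound 1 and compound 3 cannot be read.

From the compounds shown here alone, the true size of the loss stays open: the limit of > 50000 nM in this assay, at which 2 of the 3 values shown sit. It is also open whether a carboxylic acid or an amine in place of the methylcarbamoyl part would give stronger inhibition than compound 2 does.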